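The source may hold more compounds than are shown below. What is called first, only, known or untested is meant among the compounds shown, and "the series" means these compounds.

Two compounds of this series carry numbers in a functional assay on BCG823 cells (Homo sapiens) for antiproliferative activity, read by MTT assay, with a stated time of 48 h; on this read-out lower numbers stand for stronger inhibition and higher numbers for weaker inhibition. Compound 1 `O=c1cc(-c2ccccc2)oc2cc(O)c(OCCCN3CCCCC3)c(O)c12` gives 60900 nM. Compound 2 `O=c1cc(-c2ccccc2)oc2cc(OCc3ccccc3)c(OCCCCN3CCCCC3)c(O)c12` gives 3000 nM, the lowest of the two numbers, with a gap to compound 1 that lies beyond the scatter. Compound 3 `O=c1cc(-c2ccccc2)oc2cc(O)c(OCCCCN3CCCCC3)c(O)c12` has not yet been measured in this assay; it differs from compound 2 by hydrogen in place of benzyl on an oxygen on an aromatic ring. Among the measured compounds shown here, no measured pair covers this change. A weakening step is expected, larger than the scatter, because compound 1 gives 60900 nM. The expected step reads a 10-fold higher number from compound 2 to compound 3 (1.00 log units; beyond the scatter). For compound 3 the estimate is 30000 nM, within 8000 nM to 100000 nM.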

Compound 3, half-maximal inhibitory concentration: 52700 nM
The estimate for compound 3 lay 1.8-fold (0.24 log units) below the measured number; low and high end bracket the measured number.
By their numbers in this assay, from the lowest: compound 2; then compounds 3 and 1 (each within the scatter of the next).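

In this assay, among the compounds shown here, the change from benzyloxy to hydroxy gives an 18-fold higher number from compound 2 to compound 3 (1.24 log units; beyond the scatter), the first single-place step at this oxygen, and it shows that the number depends strongly on the benzyl group. With hydroxy on this oxygen, the step in chain length gives a 1.2-fold lower number from compound 1 to compound 3 (0.06 log units; within the scatter), so the chain change makes no difference that can be read here. Nothing available explains the large benzyl step. Going by these compounds, it remains open whether a smaller group such as methyl on this oxygen would keep the lower number of compound 2. On these data alone, it also remains open whether the chain length matters when benzyl is present.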